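Replacing methoxy with hydrogen in compound 2

The source may report more compounds than this note shows. Statements on the series, on what has been measured and on what is new or still open speak of the compounds shown alone.

Measured compounds:
compound 1 `Cc1ccc(C(O)(c2ccc(Cl)cc2)c2cccnc2)cc1` gives 61000 nM
compound 2 `COC(c1ccc(Cl)cc1)(c1cccnc1)c1ccccc1Cl` gives 58700 nM

Within the data shown here, both values come from an ADME assay on L6 cells (Rattus norvegicus) for cytotoxicity, read by resazurin assay, with a stated time of 72 h (on this read-out higher numbers stand for weaker inhibition and lower numbers for stronger inhibition), and lie within the usual scatter of each other, so compound 2 stands level with compound 1 on the numbers so far. The unmeasured compound 3 `Clc1ccc(C(c2cccnc2)c2ccccc2Cl)cc1` differs from compound 2 by one change: hydrogen in place of methoxy on a saturated chain carbon bound to three aromatic carbons in the structure. Among the measured compounds shown here, no two measured compounds differ in one place, so nothing measured sizes this exchange. For the measured compounds named here, the only guide is the close agreement of two values. In this assay the expected result is a 1.3-fold lower number from compound 2 to compound 3 (0.12 log units; within the scatter) as an estimated step, with no move beyond the scatter and no firm direction. For compound 3 the estimated value is 45000 nM with an expected range from 15000 nM to 100000 nM for the coming measurement.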

Compound 3, half-maximal inhibitory concentration: 62300 nM
For compound 3 the middle estimate is 1.4-fold (0.14 log units) below the measured one; low and high end bracket the measured number.
By their numbers in this assay, from the lowest: compounds 2, 1 and 3 (each within the scatter of the next).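

In this assay, the series now has its first sized exchange: hydrogen in place of methoxy on a saturated chain carbon bound to three aromatic carbons gives a step (a 1.1-fold higher number from compound 2 to compound 3 (0.03 log units; within the scatter)). On this one pair, the read-out does not separate the methoxy compound from the compound carrying only hydrogen at this position, so nothing here shows that methoxy matters for this read-out. Nothing measured on these compounds offers an explanation for this result.

The compounds shown leave open whether an amine or a carboxylic acid on the same carbon would also stay within the scatter or would move the number beyond it. A single pair also cannot show whether the exchange behaves the same way on other versions of the shared core.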